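The source may report more compounds than this note shows. Statements on the series, on what has been measured and on what is new or still open speak of the compounds shown alone.

compound 1, `CCCCc1cc(C(C)=O)c(O)cc1OCCCCC#N`, 13%
compound 2, `C=CCc1cc(C(C)=O)c(O)cc1OCCCCCCCCC#N`, 50%
compound 3, `CCc1cc(C(C)=O)c(O)cc1OCCCC(C)(C)C(N)=O`, 51%

All three were tested in an assay on isolated protein for binding affinity to leukotriene B4 receptor 1 (Homo sapiens), tested at 1 uM; a lower number here means less inhibition, a higher number more inhibition at the concentration tested (going by the name of the read-out). Compound 2 gives 50%, which is the second highest of the three numbers. Compound 3, at 51%, lies only a point from it, within the usual scatter, so the two cannot be told apart. Compound 1, at 13%, lies far below both, beyond the scatter. No pair among these three differs in a single place, so nothing can be said about any one change from the measured data alone.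

Compound 4, `C=CCCCCOc1cc(O)c(C(C)=O)cc1CC=C`, has not been measured. It differs from compound 2 in one place: vinyl in place of 4-cyanobutyl on a saturated chain carbon, four bonds along the chain from an oxygen on an aromatic ring. The nitrile end group leaves together with most of the chain, so compound 4 carries a shorter ether chain without an acceptor at its end. Compound 1, whose shorter nitrile chain gives 13%, is the only hint that a shorter chain goes with a lower number. On that basis compound 4 is expected to fall below compound 2, with an estimated step of a number 25 percentage points lower from compound 2 to compound 4 (beyond the scatter) beyond the scatter. The estimate for compound 4 is 25%, with a range from 5% to 48%.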

Compound 4, a percentage reported as inhibition, at one concentration (the size of the read-out at that concentration, not a potency): 27%
For compound 4 the middle estimate is 2 percentage points below the measured one, within the range that was stated.
By their numbers in this assay, from the lowest: compound 1; then compound 4; then compounds 2 and 3 (each within the scatter of the next).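

Replacing 4-cyanobutyl with vinyl, on a saturated chain carbon, four bonds along the chain from an oxygen on an aromatic ring, gives in this assay a number 23 percentage points lower from compound 2 to compound 4 (beyond the scatter). Among the compounds shown here, this is the first change that can be read on its own, and it shows that the number at this position responds to what stands at the end of the ether chain: six heavy atoms, including the nitrile, leave, and two carbons enter. No supporting measurement is available to explain the step.

The nitrile and the chain length leave together, so the compounds shown do not tell which of the two accounts for the step. They also leave open how a carboxylic acid or an amine at the end of this chain would read.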